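Thioether lipopeptide series: amide nitrogen substituent and receptor agonism

A few compounds are considered here, and "the series" means these few. Any claim that something is new, unique, unknown or untested is made for them only; others in the source may bear on it.

Compounds measured so far:
compound 1 `CCCCCCCCCCCC(=O)OC[C@H](CSC[C@@H](N)C(=O)N[C@H](C)CO)OC(=O)CCCCCCCCCCC`, 22200 nM
compound 2 `CCCCCCCCCCCC(=O)OC[C@H](CSC[C@@H](N)C(=O)NCCCCCCO)OC(=O)CCCCCCCCCCC`, 33 nM
compound 3 `CCCCCCCCCCCC(=O)OC[C@H](CSC[C@@H](N)C(=O)NC(C)CCc1ccccc1)OC(=O)CCCCCCCCCCC`, 160 nM

In an assay on HEK293 cells for agonist activity at Toll-like receptor 2 (Homo sapiens) (a higher number here means that more compound is needed for the effect, a lower number that less compound is needed), compound 2 gives the lowest number of the three; compound 3 is nearest, compound 1 furthest. The step from compound 2 to compound 4 `CCCCCCCCCCCC(=O)OC[C@H](CSC[C@@H](N)C(=O)NC(C)CCC(C)C)OC(=O)CCCCCCCCCCC` changes (1,4-dimethylpentyl in place of 6-hydroxyhexyl on an amide-type nitrogen).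

Among the measured compounds shown here, only one measured step bears on this: a 4.8-fold higher number from compound 2 to compound 3 (0.69 log units; beyond the scatter), where a group with a hydroxyl is likewise replaced by a hydrocarbon group branched at the first carbon. For the measured compounds named here, compound 1 carries a hydroxyl and is branched, yet is far weaker, so no second reference step applies. A modest rise is therefore expected for compound 4, a 4.5-fold higher number from compound 2 to compound 4 (0.66 log units; beyond the scatter), of about the size seen for compound 3. The expected value for compound 4 is 150 nM, with a range of 40 nM to 600 nM.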

Compound 4, half-maximal effective concentration: 190 nM
Beside the measured number, compound 4's estimate is 1.3-fold (0.10 log units) below it; low and high end bracket the measured number.
By their numbers in this assay, from the lowest: compound 2; then compounds 3 and 4 (each within the scatter of the next); then compound 1.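

In this assay, 1,4-dimethylpentyl in place of 6-hydroxyhexyl gives a 5.8-fold higher number from compound 2 to compound 4 (0.76 log units; beyond the scatter), so the rise seen with compound 3 does not require a phenyl. Isopropyl in place of phenyl gives a 1.2-fold higher number from compound 3 to compound 4 (0.07 log units; within the scatter), and 1,4-dimethylpentyl in place of 1-(hydroxymethyl)ethyl gives a 120-fold lower number from compound 1 to compound 4 (2.07 log units; beyond the scatter), so branching alone does not bring the high number of compound 1. Nothing available explains these differences.

Whether the hydroxyl or the unbranched chain sets compound 2 apart stays open, as the compounds shown change both together. An unbranched hexyl chain, or an amine at the end of the hexyl chain, would separate the two.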